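The source may report more compounds than this note shows. Statements on the series, on what has been measured and on what is new or still open speak of the compounds shown alone.

Measured compounds in a functional assay on J774.A1 cells (Mus musculus) for inhibition, read by immunoassay, with a stated time of 12 h, tested at 30 uM; on this read-out higher numbers stand for more inhibition at the one concentration tested (going by the name of the read-out) and lower numbers for less inhibition:
compound 1 `CC(C)=CCOc1ccccc1C1CC(=O)c2ccccc2O1` — 40.3%
compound 2 `CCCOc1ccccc1C1CC(=O)c2ccccc2O1` — 43.6%
compound 3 `O=C1CC(c2ccccc2OCc2ccc(F)cc2)Oc2ccccc21` — 42.1%

Compound 1 has the lowest of the three numbers, but its nearest neighbour, compound 3, sits only a number 1.8 percentage points higher from compound 1 to compound 3 (within the scatter), and the furthest, compound 2, only a number 3.3 percentage points higher from compound 1 to compound 2 (within the scatter), so the three values cannot be told apart. Between compound 2 and compound 3 the difference is likewise small, a number 1.5 percentage points lower from compound 2 to compound 3 (within the scatter).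

Compound 4 `COc1ccccc1C1CC(=O)c2ccccc2O1` is the next compound in this series. It differs from compound 1 in one place: hydrogen in place of 2-methylprop-1-en-1-yl on a saturated chain carbon bound to an oxygen on an aromatic ring.

Among the measured compounds shown here, the steps that bear on this change are the two that replace the same 2-methylprop-1-en-1-yl group on the same saturated chain carbon bound to an oxygen on the aromatic ring: ethyl gave a number 3.3 percentage points higher from compound 1 to compound 2 (within the scatter) and 4-fluorophenyl gave a number 1.8 percentage points higher from compound 1 to compound 3 (within the scatter). Both stayed within the scatter, whether the group grew or shrank. Hydrogen is a smaller replacement than either, and nothing in the three numbers suggests that the size of this group moves the read-out in this assay. The expected step is therefore none beyond the scatter, a number 1.7 percentage points higher from compound 1 to compound 4 (within the scatter).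

Compound 4 is estimated at 42% in this assay, with a range from 30% to 54%.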

Compound 4, a percentage reported as inhibition, at one concentration (the size of the read-out at that concentration, not a potency): 38.3%
Compound 4: the middle estimate sits 3.7 percentage points above what was measured; the measured number falls inside the stated range.
By their numbers in this assay, from the lowest: compounds 4, 1, 3 and 2 (each within the scatter of the next).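

In this assay, among the compounds shown here, compound 4 takes the group on the saturated chain carbon bound to an oxygen on an aromatic ring down to hydrogen, leaving only methoxy where compound 1 carries (3-methylbut-2-en-1-yl)oxy, and this removal gives a number 2 percentage points lower from compound 1 to compound 4 (within the scatter), whereas the earlier steps only exchanged one group for another. The comparisons with the other two compounds read the same way, with a number 3.8 percentage points lower from compound 3 to compound 4 (within the scatter) and a number 5.3 percentage points lower from compound 2 to compound 4 (within the scatter). At this place, then, the read-out stays within the scatter across hydrogen, ethyl, 2-methylprop-1-en-1-yl and 4-fluorophenyl, no compound shown goes against this, and neither the double bond nor the aromatic ring of the larger groups is required to hold the number at this level.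

No measurement at hand offers any reason for this flat result. On these data alone, whether a chain ending in an amine or a carboxylic acid, or a longer chain, would move the number beyond the scatter stays open, as does whether the same flatness would hold at other concentrations, since all four values come from a single concentration in this assay.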